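Aminophenyl for methylaminopropyl on the anilinic nitrogen of the core

A few compounds are considered here, and "the series" means these few. Any claim that something is new, unique, unknown or untested is made for them only; others in the source may bear on it.

For compound 1 `N[C@H]1CC[C@H](Nc2c(C(=O)NCc3ccccn3)nc(Br)c3cccnc23)CC1` the entry in a functional assay on SK-BR-3 cells (Homo sapiens) for cytotoxicity, read by MTT assay, with a stated time of 72 h (a higher number here means a weaker inhibitor, a lower number a stronger inhibitor), reads "not determined" (no result reported), so no result is reported for it. Compound 2 `CNCCCNc1c(C(=O)NCc2ccc(F)cc2)nc(Br)c2cccnc12` gives 1000 nM in this assay. Compound 3 `O=C(NCCCNc1c(C(=O)NCc2ccc(F)cc2)nc(Br)c2cccnc12)c1ccccc1` gives 1000 nM in this assay; the step of no change at the digits printed from compound 2 to compound 3 (within the scatter) lies within the scatter, so compound 2 stands level with compound 3 on the numbers shown, and compound 1 adds no further anchor.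

Compound 4 `Nc1cccc(Nc2c(C(=O)NCc3ccc(F)cc3)nc(Br)c3cccnc23)c1` differs from compound 2 by 3-aminophenyl in place of 3-(methylamino)propyl on a nitrogen on an aromatic ring. Among the measured compounds shown here, the only measured step touching the same substituent, no change at the digits printed from compound 2 to compound 3 (within the scatter), exchanged one group on an amine nitrogen of the 3-(methylamino)propyl chain for another without moving the read-out. That step kept the chain in place, whereas here the whole chain gives way to a ring, so it bears on compound 4 only loosely: it shows that this part of the molecule tolerated one change, and nothing more. For the measured compounds named here, with no measured step of the kind here, the step of no change at the digits printed from compound 2 to compound 4 (within the scatter) is expected to show no change beyond the scatter, held with low confidence and a wide range. Compound 4 is therefore estimated at 1000 nM, with a range from 300 nM to 3500 nM.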

Compound 4, half-maximal inhibitory concentration: > 10000 nM
Compound 4 gave a limit, no number (the forecaster's own chance of this, stated with the estimate: 10%); middle value at least 10-fold (1.00 log units) away from the limit.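

In this assay, 3-aminophenyl in place of 3-(methylamino)propyl on a nitrogen on an aromatic ring gives an at least 10-fold higher number from compound 2 to compound 4 (1.00 log units; beyond the scatter), so this position is not indifferent to the group it carries. The reading for compound 4 is a limit of the assay and not a number: the limit of > 10000 nM in this assay, at which 1 of the 4 values shown sits. The earlier step, no change at the digits printed from compound 2 to compound 3 (within the scatter), kept the chain and changed only the group on its amine nitrogen, so the tolerance seen there does not extend to exchanging the whole chain for a ring.

The compounds shown do not separate the arrival of the aromatic ring from the loss of the chain, since both happen in the one step. From the compounds shown here alone, it remains open whether an unsubstituted phenyl, a saturated ring carrying a primary amine, or a longer chain ending in an amine would read closer to compound 2 or to compound 4, and compound 1, with "not determined" (no result reported), gives no guidance on this.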